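Swapping a Trifluoromethyl for a Nitro on Two Related Cores

A few compounds are considered here, and "the series" means these few. Any claim that something is new, unique, unknown or untested is made for them only; others in the source may bear on it.

Four compounds share a chain that links a ring bearing methyl groups to a benzene ring carrying a single extra group. Compound 1 is `CC1=C(/C=C/C(=O)/C=C/c2cccc(C(F)(F)F)c2)C(C)(C)CCC1` and compound 2 is `CC1=C(/C=C/C(=O)/C=C/c2cccc([N+](=O)[O-])c2)C(C)(C)CCC1`; the change from the first to the second is nitro in place of trifluoromethyl on an aromatic carbon. Compound 3 is `CC1=CCCC(C)(C)C1/C=C/C(=O)/C=C/c1cccc(C(F)(F)F)c1` and is built on a differently joined core; the difference between the two cores is not broken down here. Compound 4, `CC1=CCCC(C)(C)C1/C=C/C(=O)/C=C/c1cccc([N+](=O)[O-])c1`, is not yet measured; its change from compound 3 is nitro in place of trifluoromethyl on an aromatic carbon, the same change as before.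

In a functional assay on LNCaP cells (Homo sapiens) for cytotoxicity, read by MTT assay, with a stated time of 72 h (a higher number here means a weaker inhibitor, a lower number a stronger inhibitor), compound 1 gives 2800 nM and compound 2 gives 2700 nM, so a 1.0-fold lower number from compound 1 to compound 2 (0.02 log units; within the scatter). Compound 3 gives 1000 nM, the lowest of the three numbers, and its gap to the others lies beyond the scatter.

Because the earlier step of a 1.0-fold lower number from compound 1 to compound 2 (0.02 log units; within the scatter) was flat, compound 4 is expected to sit close to compound 3, and the estimated step is no change at the digits printed from compound 3 to compound 4 (within the scatter). For compound 4 the estimate in this assay is 1000 nM, with a likely range from 500 nM to 2000 nM.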

Compound 4, half-maximal inhibitory concentration: 3300 nM
The estimate for compound 4 lay 3.3-fold (0.52 log units) below the measured number; the whole stated range lies below it.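

In this assay placing nitro where trifluoromethyl stood gives a 3.3-fold higher number from compound 3 to compound 4 (0.52 log units; beyond the scatter) and so does not leave the number flat on this core, as it did on the core of compound 1. The change therefore does not carry over at the same size from one core to the other, and the gap between the two steps is larger than repeated measurements would be expected to produce: the same change on two cores in this assay, a 1.0-fold lower number (0.02 log units; within the scatter) from compound 1 to compound 2 and a 3.3-fold higher number (0.52 log units; beyond the scatter) from compound 3 to compound 4, 3.4-fold (0.53 log units) apart, beyond the scatter of two such steps. This shows that, for these two pairs of compounds, the effect of the swap depends on the core it is made on, but it does not show which feature of the core matters or what the swap would do on a third core.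

On these data alone, it remains open whether another group on the same aromatic carbon, such as a nitrile or an amine, would also give different steps on the two cores. The compounds shown also leave open whether the gap between the cores would appear in cells other than LNCaP.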